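Acetoxymethyl to hydroxymethyl in the antiproliferative series

The source may hold more compounds than are shown below. What is called first, only, known or untested is meant among the compounds shown, and "the series" means these compounds.

Values so far in a functional assay on MCF7 cells (Homo sapiens) for antiproliferative activity, read by MTT assay, with a stated time of 48 h (a lower number here means a stronger inhibitor, a higher number a weaker inhibitor), are these:
- compound 1 `CC(C)=CCC[C@]1(C)/C=C/[C@@H](OC(=O)C=C(C)C)[C@](C)(O)/C=C/C(=O)/C(CF)=C\C1` gives 240 nM
- compound 2 `CC(=O)OC/C1=C/C[C@](C)(CCC=C(C)C)/C=C/[C@@H](OC(=O)C=C(C)C)[C@](C)(O)/C=C/C1=O` gives 4510 nM
- compound 3 `CC(=O)OC/C1=C/C[C@](C)(CCC=C(C)C)/C=C/[C@@H](OC(=O)C=C(C)C)[C@](C)(OC(C)=O)/C=C/C1=O` gives 3990 nM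

Compound 3 at 3990 nM sits with compound 2 at 4510 nM within the scatter, while compound 1 at 240 nM lies far lower. Compound 4 `CC(=O)O[C@]1(C)/C=C/C(=O)/C(CO)=C\C[C@](C)(CCC=C(C)C)/C=C/[C@H]1OC(=O)C=C(C)C` comes from compound 3 by one change, (hydrogen in place of acetyl on an oxygen on a saturated carbon), which also reads acetoxymethyl to hydroxymethyl. Among the compounds with values here, two measured steps bear on it. The step of a 1.1-fold lower number from compound 2 to compound 3 (0.05 log units; within the scatter) puts acetyl in place of hydrogen on a different oxygen and stays within the scatter. The step of a 19-fold higher number from compound 1 to compound 2 (1.27 log units; beyond the scatter) puts acetoxy in place of fluoro on the saturated chain carbon that is changed here, and it is large. Within the data shown here, a change at that carbon has therefore moved the number strongly once, but no measured compound carries hydroxymethyl, so the direction is weakly held. The expected step is a 1.6-fold lower number from compound 3 to compound 4 (0.20 log units; within the scatter) and the uncertainty runs wide on both sides. For compound 4 the estimate is 2500 nM with an expected range from 700 nM to 7000 nM in this assay for now.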

Compound 4, half-maximal inhibitory concentration: 2320 nM
Beside the measured number, compound 4's estimate is 1.1-fold (0.03 log units) above it; measured number inside the range.
By their numbers in this assay, from the lowest: compound 1; then compounds 4, 3 and 2 (each within the scatter of the next).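

In this assay, the step of a 1.7-fold lower number from compound 3 to compound 4 (0.24 log units; within the scatter) gives a reading for hydroxymethyl at this chain carbon, with acetyl still on the other oxygen, and it stays within the scatter. Acetoxymethyl and hydroxymethyl therefore read alike in this setting, so the large step of a 19-fold higher number from compound 1 to compound 2 (1.27 log units; beyond the scatter) remains the only one beyond the scatter at this carbon, and it involves fluoro rather than hydroxy. No supporting data bear on why these two groups read alike.

Still open, on these data alone, is how fluoro reads with acetyl on the other oxygen, since compound 1 at 240 nM carries a free hydroxy there. Also open, as far as these compounds go, is how an amine, a carboxylic acid or a longer chain on this carbon would read against hydroxymethyl and fluoro.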